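The source may report more compounds than this note shows. Statements on the series, on what has been measured and on what is new or still open speak of the compounds shown alone.

Measured in a functional assay on PC-3 cells (Homo sapiens) for antiproliferative activity, read by MTT assay, with a stated time of 72 h; on this read-out higher numbers stand for weaker inhibition and lower numbers for stronger inhibition:
- compound 1 `CCN(CC)CCNC(=O)c1ccc(C(CC)(CC)c2ccc(OCC(O)C(C)(C)C)c(C)c2)n1CC`: 2800 nM
- compound 2 `CCn1c(C(=O)NCc2ccc(OC)cc2)ccc1C(CC)(CC)c1ccc(C#CC(O)(CC)CC)c(C)c1`: > 50000 nM (a limit)
- compound 3 `CCCCC(=O)c1ccc(C(CC)(CC)c2ccc(C#CC(O)(CC)CC)c(C)c2)n1CC`: > 50000 nM (a limit)

Compound 3 has no numerical value in this assay, only the limit > 50000 nM. The same holds for compound 2, so the picture is the limit of > 50000 nM in this assay, at which 2 of the 3 values shown sit. Compound 4 `CCn1c(C(=O)NCCCO)ccc1C(CC)(CC)c1ccc(C#CC(O)(CC)CC)c(C)c1` is compound 3 with (3-hydroxypropyl)amino in place of butyl on a carbonyl carbon.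

Going by the values given here, the one measured step at this place is a step that the two limits leave unreadable from compound 2 to compound 3. It gives no size to carry over, and compound 2 shows that an amino group on this carbonyl carbon can still leave a compound at the limit. Compound 1 alone gives a number, 2800 nM, but it differs from compound 3 in more than this one place, so it offers only weak support for any gain.

No clear change is therefore expected, though a small move toward stronger inhibition cannot be ruled out. The expected step is an at least 1.2-fold lower number from compound 3 to compound 4 (0.09 log units; that floor lies within the scatter). Compound 4 is estimated at 40000 nM, with an expected range of 12000 nM to 80000 nM.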

Compound 4, half-maximal inhibitory concentration: > 50000 nM
Compound 4: a limit, no number; the forecaster's own chance of this, stated with the estimate: 65%; middle value at least 1.2-fold (0.09 log units) away from the limit.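

In this assay, going by these compounds alone, compound 4 gives only a limit, so no step among compound 2, compound 3 and compound 4 can be read, and the picture stays as it was: the limit of > 50000 nM in this assay, at which 3 of the 4 values shown sit. The compounds shown leave open how much the group on the carbonyl carbon changes inhibition.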